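The source may report more compounds than this note shows. Statements on the series, on what has been measured and on what is new or still open speak of the compounds shown alone.

Measured in an ADME assay on MT4 cells (Homo sapiens) for cytotoxicity, read by MTT assay; a higher number here means that more compound is tolerated, a lower number that less compound is tolerated:
- Compound 1 `Cc1cc(C)cc(S(=O)(=O)c2c(C(=O)NC(C)C(=O)NCCn3c(C)cnc3[N+](=O)[O-])[nH]c3ccc(Cl)cc23)c1`: 16000 nM
- Compound 2 `Cc1cc(C)cc(S(=O)(=O)c2c(C(=O)NCc3cccc(F)c3F)[nH]c3ccc(Cl)cc23)c1`: > 51100 nM, a limit
- Compound 3 `Cc1cc(C)cc(S(=O)(=O)c2c(C(=O)NCC(=O)NCc3ccncc3)[nH]c3ccc(Cl)cc23)c1`: > 48900 nM, a limit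

Compound 3 has no number in this assay, only the limit > 48900 nM. Compound 4 `COc1cccc(F)c1CNC(=O)c1[nH]c2ccc(Cl)cc2c1S(=O)(=O)c1cc(C)cc(C)c1` differs from it in one place: 2-fluoro-6-methoxyphenyl in place of ((pyridin-4-yl)methyl)carbamoyl on a saturated chain carbon bound to an amide-type nitrogen. This turns the (((pyridin-4-yl)methyl)carbamoyl)methyl group into 2-fluoro-6-methoxybenzyl.

Going by the values given here, the one measured step that bears on this change is a step that the two limits leave unreadable from compound 2 to compound 3. That step replaced 2,3-difluorophenyl with the same ((pyridin-4-yl)methyl)carbamoyl group, but its size cannot be read. Compound 4 again carries a substituted phenyl at that place, as compound 2 does, so compound 2 is its closest guide. Compound 1, with a different chain, gives a true number of 16000 nM, so a measurable value remains possible.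

No step beyond the usual scatter is expected, in either direction, and the estimate is an at least 1.2-fold lower number from compound 3 to compound 4 (0.08 log units; that floor lies within the scatter). For compound 4 the estimated value is 40000 nM, with an expected range of 15000 nM to 60000 nM.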

Compound 4, half-maximal cytotoxic concentration: > 49900 nM
Compound 4: no number, only a limit; the forecaster's own chance of this, stated with the estimate: 60%; at least 1.2-fold (0.09 log units) between middle value and limit.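

Compound 4 gives only a limit in this assay, as do compound 2 and compound 3, so none of the steps among these three compounds can be read. The compounds shown leave open whether 2-fluoro-6-methoxyphenyl, 2,3-difluorophenyl or ((pyridin-4-yl)methyl)carbamoyl changes the tolerated concentration at all.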